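The source may hold more compounds than are shown below. What is called first, only, known or untested is meant among the compounds shown, and "the series" means these compounds.

Three members of the series have been read in a physicochemical assay for solubility, in phosphate buffer, measured as kinetic solubility, at pH 7.4; a higher number here means a more soluble compound, a lower number a less soluble compound: compound 1 `Cc1ccc(C)c(-c2nc(CN3CCC(C(=O)NCCCN4C[C@H](C)C[C@H](C)C4)CC3)c(C)o2)c1`, compound 2 `Cc1ccccc1-c1nc(CN2CCC(C(=O)NCCN3C[C@H](C)C[C@H](C)C3)CC2)c(C)o1` and compound 3 `Cc1cccc(Cl)c1-c1nc(CN2CCC(C(=O)NCCCN3CCC(C)(C)CC3)CC2)c(C)o1`. Within the data shown here, compound 1 gives 56.1 ug/mL, the only actual number among the three. Compound 2 is reported only as a limit, > 67 ug/mL. Compound 3 is likewise reported only as a limit, > 74 ug/mL.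

Next in line is compound 4 `Cc1cccc(F)c1-c1nc(CN2CCC(C(=O)NCCCN3C[C@H](C)C[C@H](C)C3)CC2)c(C)o1`, which has 2-fluoro-6-methylphenyl in place of 2,5-dimethylphenyl on an aromatic carbon of the core of compound 1 (2-fluoro-6-methylphenyl in place of 2,5-dimethylphenyl on an aromatic carbon). Among the measured compounds shown here, no two measured compounds differ in one place only, so the series offers no measured size for a change of this kind. The expectation therefore rests on compound 1 at 56.1 ug/mL, and no shift beyond the usual scatter is expected in either direction. The expected step of a 1.1-fold higher number from compound 1 to compound 4 (0.03 log units; within the scatter) is accordingly small. For compound 4 the estimate in this assay is 60 ug/mL, with an expected range of 32 ug/mL to 85 ug/mL.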

Compound 4, solubility: > 72 ug/mL
Compound 4: a limit, no number; the forecaster's own chance of this, stated with the estimate: 40%; at least 1.2-fold (0.07 log units) between middle value and limit.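

Among these compounds, this is the first pair that differs in one place, and 2-fluoro-6-methylphenyl in place of 2,5-dimethylphenyl on an aromatic carbon of the shared core reads in this assay only as a floor, an at least 1.2-fold higher number from compound 1 to compound 4 (0.10 log units; that floor lies within the scatter). Compound 4 is reported as a limit and not a number: the limit of > 72 ug/mL in this assay, at which 1 of the 4 values shown sits. Going by these compounds, at this position the change therefore shows no loss beyond the usual scatter, while the full size of the step stays unknown.

The compounds shown leave open whether the fluorine or the changed placement of the methyl group carries the step. They also leave open how this position responds to a group of another kind on the phenyl ring, such as an amine or a carboxylic acid.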